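Piperidinyl to Diethylamino on the Shared Core

The source may report more compounds than this note shows. Statements on the series, on what has been measured and on what is new or still open speak of the compounds shown alone.

Measured compounds:
- compound 1, `COC(=O)C(C)c1ccc(-c2ccc(C(=O)/C=C/c3ccc(CN(C)C)c(O)c3)cc2)c(F)c1`: 430 nM
- compound 2, `COC(=O)C(C)c1ccc(-c2ccc(C(=O)/C=C/c3ccc(CN4CCCCC4)c(O)c3)cc2)c(F)c1`: 430 nM

Both compounds were tested in an assay on isolated protein for inhibition of Amine oxidase [flavin-containing] B (Homo sapiens), read by fluorescence, with a stated time of 30 min; a higher number here means a weaker inhibitor, a lower number a stronger inhibitor. For the measured compounds named here, the single measured step, no change at the digits printed from compound 1 to compound 2 (within the scatter), shows that trading one amine for another on the saturated chain carbon bound to an aromatic carbon left the read-out where it was. Compound 2 therefore stands level with compound 1 at the digits shown, and nothing in the two numbers separates them.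

Compound 3, `CCN(CC)Cc1ccc(/C=C/C(=O)c2ccc(-c3ccc(C(C)C(=O)OC)cc3F)cc2)cc1O`, is the next variation at the same position. Its difference from compound 2 is diethylamino in place of piperidin-1-yl on a saturated chain carbon bound to an aromatic carbon. Going by the values given here, the only step that bears on this change is the one from compound 1 to compound 2, and that step was flat within the scatter. A second amine swap at the same place, with the same donor and acceptor count, gives no reason from the data in hand to expect movement in this assay.

The expected step is no change at the digits printed from compound 2 to compound 3 (within the scatter), that is, none beyond the scatter. Compound 3 is estimated at 430 nM, with a range from 200 nM to 950 nM.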

Compound 3, half-maximal inhibitory concentration: 430 nM
Estimate against measurement, compound 3: no gap at the digits printed; the range from low to high includes it.
By their numbers in this assay, from the lowest: compounds 1, 2 and 3 (each within the scatter of the next).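

In this assay, replacing the ring of piperidin-1-yl with the open chains of diethylamino gives (no change at the digits printed from compound 2 to compound 3 (within the scatter)), so on a saturated chain carbon bound to an aromatic carbon, this read-out does not depend on the amine being held in a ring. The comparison of the two open-chain amines adds a second point, (no change at the digits printed from compound 1 to compound 3 (within the scatter)), which shows that diethylamino and dimethylamino also cannot be told apart here, so the three amines now form a flat set rather than a single matched pair. Nothing available explains why these three groups read alike.

Going by these compounds, these three amines are close relatives, so it remains open whether the flat read-out would hold for morpholin-4-yl, which carries an oxygen in its ring, for a smaller amine such as methylamino, or for a carboxylic acid in place of the amine at this position. On these data alone, it is also open whether the same indifference to the amine would persist if the methyl ester of the shared core were replaced by a carboxylic acid.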